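The source may report more compounds than this note shows. Statements on the series, on what has been measured and on what is new or still open speak of the compounds shown alone.

Measured compounds:
compound 1, `CC(C)c1onc(-c2c(Cl)cccc2Cl)c1COc1ccc(-c2nc3ccc(C(=O)O)cc3n2CC2CC2)cc1`: 2650 nM
compound 2, `CC(=O)C1CCC(Cn2c(-c3ccc(OCc4c(-c5c(Cl)cccc5Cl)noc4C(C)C)cc3)nc3ccc(C(=O)O)cc32)CC1`: > 10000 nM

Both values come from an assay on HEK-293T cells for antagonist activity at vitamin D3 receptor (Homo sapiens), read by a luciferase reporter, with a stated time of 24 h; on this read-out higher numbers stand for weaker inhibition and lower numbers for stronger inhibition. Compound 2 gives only a limit of the assay and not a number; compound 2 stands at the limit of > 10000 nM in this assay, at which 1 of the 2 values shown sits. Compound 1 gives a proper number, 2650 nM. Within the data shown here, the single measured step, an at least 3.7-fold higher number from compound 1 to compound 2 (0.57 log units; beyond the scatter), is the exchange of cyclopropyl for 4-acetylcyclohexyl on the saturated chain carbon bound to the aromatic nitrogen.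

Compound 3, `CC(C)c1onc(-c2c(Cl)cccc2Cl)c1COc1ccc(-c2nc3ccc(C(=O)O)cc3n2C2CCC2)cc1`, differs from compound 2 by cyclobutyl in place of (4-acetylcyclohexyl)methyl on an aromatic nitrogen. This is in kind the measured step run backwards: the acetyl-bearing six-membered ring and its chain carbon leave, and a small saturated ring, nearer to the cyclopropyl of compound 1, enters, now bound directly to the aromatic nitrogen. Given that an at least 3.7-fold higher number from compound 1 to compound 2 (0.57 log units; beyond the scatter) raised the number beyond the scatter, the number is expected to come back down for compound 3 in this assay, at least modestly, toward where compound 1 sits. Compound 3 is therefore estimated at 3000 nM, with a range of 1000 nM to 10000 nM. The expected step is an at least 3.3-fold lower number from compound 2 to compound 3 (0.52 log units; beyond the scatter).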

Compound 3, half-maximal inhibitory concentration: 1100 nM
Compound 3: middle estimate off by 2.7-fold (0.44 log units), on the high side; the measured number falls inside the stated range.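

In this assay, the exchange of (4-acetylcyclohexyl)methyl for cyclobutyl on the aromatic nitrogen brings an at least 9.0-fold lower number from compound 2 to compound 3 (0.95 log units; beyond the scatter), so removing the larger group restores measurable inhibition and takes it past that of compound 1. Compound 2 gives a limit of the assay and not a number: the limit of > 10000 nM in this assay, at which 1 of the 3 values shown sits.

New here is that this position also separates two small saturated groups: cyclobutyl in place of cyclopropylmethyl brings a 2.4-fold lower number from compound 1 to compound 3 (0.38 log units; beyond the scatter), beyond the scatter, which makes compound 3 the strongest inhibitor of the three.

That exchange changes the ring size and removes the chain carbon at once, so the shown compounds do not assign the gain to either change; cyclopropyl bound directly to the aromatic nitrogen, or cyclobutylmethyl, would separate the two. On these data alone, it also stays open whether the acetyl group or the six-membered ring accounts for the loss in compound 2, a question that plain cyclohexylmethyl, or an amine in place of the acetyl group, would address.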